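Replacing an aryl group with cyclopentyl on a piperazine-like ring

The source may hold more compounds than are shown below. What is called first, only, known or untested is meant among the compounds shown, and "the series" means these compounds.

Of the compounds shown here, three sharing one core have been tested in an assay on CHO cells for displacement of a labelled ligand from adenosine receptor A3 (Homo sapiens), read by scintillation counting, with a stated time of 120 min, tested at 10 uM; a lower number here means less inhibition, a higher number more inhibition at the concentration tested (going by the name of the read-out). Compound 1 `Nc1scc(CN2CCN(c3ccc(Cl)cc3F)CC2)c1C(=O)c1ccc(Cl)cc1` gives 1% in this assay. Compound 2 `Nc1scc(CN2CCC(c3ccc(Cl)cc3)CC2)c1C(=O)c1ccc(Cl)cc1` gives 6% in this assay, and compound 3 `Nc1scc(CN2CCN(c3cccc(F)c3)CC2)c1C(=O)c1cccc(C(F)(F)F)c1` gives 0% in this assay. The number for compound 1 lies within the usual scatter of both companions: the value of compound 3 is nearby, and even the value of compound 2, the furthest of the three, is separated from it by no more than that scatter. None of the three values is distinguished from the others.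

Compound 4 `Nc1scc(CN2CCN(C3CCCC3)CC2)c1C(=O)c1ccc(Cl)cc1` has not yet been measured. It differs from compound 1 in one place: cyclopentyl in place of 4-chloro-2-fluorophenyl on an amine nitrogen in a ring. Among the compounds with values here, no measured pair shows what this exchange does. Given that all three measured compounds sit at the bottom of the scale in this assay, the step of a number 2 percentage points higher from compound 1 to compound 4 (within the scatter) is expected to stay within the scatter, with no clear direction. Compound 4 is therefore estimated to give 3% in this assay, somewhere between -6% and 14%.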

Compound 4, a percentage reported as inhibition, at one concentration (the size of the read-out at that concentration, not a potency): 3%
Compound 4: the middle estimate sits on the measured number at the digits printed; the measured number falls inside the stated range.
By their numbers in this assay, from the lowest: compounds 3, 1, 4 and 2 (each within the scatter of the next).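

In this assay, cyclopentyl in place of 4-chloro-2-fluorophenyl on the amine nitrogen in the ring gives a number 2 percentage points higher from compound 1 to compound 4 (within the scatter), the first step read at this position. At this position, then, the assay does not tell a six-membered aromatic ring of carbon only, carrying fluorine and chlorine, from a five-membered non-aromatic ring of carbon only. Nothing at hand offers a reason for this result.

Since this single step starts from a compound near the bottom of the scale, it cannot show whether any group at this position would give a clearly higher number. A carboxylic acid, a primary amine or a longer alkyl chain on this nitrogen remains an open case, and so does the same exchange on a core carrying a different aryl ketone.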